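Amide series: amidine replaced by methyl-oxadiazole on the pyridine

A few compounds are considered here, and "the series" means these few. Any claim that something is new, unique, unknown or untested is made for them only; others in the source may bear on it.

Compound 1: `CC(C)(C)c1ccc(NC(=O)c2ccc(-c3ncccc3C#N)cc2)cc1` gives 30 nM in a functional assay for antagonist activity at transient receptor potential cation channel subfamily V member 1 (Homo sapiens), read by FLIPR; a lower number here means a stronger inhibitor, a higher number a weaker inhibitor.
Compound 2: `CC(C)(C)c1ccc(NC(=O)c2ccc(-c3ncccc3NS(C)(=O)=O)cc2)cc1` gives 152 nM in this assay.
Compound 3: `CC(C)(C)c1ccc(NC(=O)c2ccc(-c3ncccc3C(=N)N)cc2)cc1` gives > 4000 nM in this assay.
Compound 4: `Cc1nnc(-c2cccnc2-c2ccc(C(=O)Nc3ccc(C(C)(C)C)cc3)cc2)o1` is not yet measured.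

Compound 3 sits at the weak end of the three measured compounds, and its value is a limit of the assay the limit of > 4000 nM in this assay, at which 1 of the 3 values shown sits, rather than a number. The shared core is kept in compound 4; the change is a group of 6 heavy atoms (3 carbon, 2 nitrogen, 1 oxygen; one five-membered aromatic ring with 3 hetero atoms) in place of a group of 3 heavy atoms (1 carbon, 2 nitrogen; no ring), on an aromatic carbon.

For the measured compounds named here, two measured steps bear on this move. Both neighbours of compound 3 on the ring carbon that carries the variable group gave far lower numbers: an at least 130-fold higher number from compound 1 to compound 3 (2.12 log units; beyond the scatter) and an at least 26-fold higher number from compound 2 to compound 3 (1.42 log units; beyond the scatter). Going by the values given here, the donor-bearing group thus stands out as the one change that lost activity, while the smaller nitrile and the methanesulfonamido group held it, with a 5.1-fold higher number from compound 1 to compound 2 (0.70 log units; beyond the scatter) separating those two. Removing the donors again in compound 4 is therefore expected to give a large fall in the number, an at least 50-fold lower number from compound 3 to compound 4 (1.69 log units; beyond the scatter), back toward the range of compounds 1 and 2. For compound 4 the estimated value is 80 nM, with a range from 20 nM to 500 nM.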

Compound 4, half-maximal inhibitory concentration: 387 nM
For compound 4 the middle estimate is 4.8-fold (0.68 log units) below the measured one, within the range that was stated.
By their numbers in this assay, from the lowest: compound 1; then compound 2; then compound 4. At a limit, above all of these: compound 3.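

In this assay the 5-methyl-1,3,4-oxadiazol-2-yl group, with 0 hydrogen-bond donors, regains much of what the amidine group lost, with an at least 10-fold lower number from compound 3 to compound 4 (1.01 log units; beyond the scatter) as a step read against a limit. Compound 3 holds a limit and not a number: the limit of > 4000 nM in this assay, at which 1 of the 4 values shown sits. This five-membered aromatic ring is therefore accepted at the carbon ortho to a large group, yet it does not match the nitrile or the methanesulfonamido group, with a 13-fold higher number from compound 1 to compound 4 (1.11 log units; beyond the scatter) and a 2.5-fold higher number from compound 2 to compound 4 (0.41 log units; beyond the scatter) remaining, so removing the donors of compound 3 does not by itself return the number to that of compound 1.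

Going by these compounds, it remains open whether the methyl on the ring contributes to this gap. Also open, on these data alone, is how a plain 1,3,4-oxadiazol-2-yl, a primary carboxamide or a carboxylic acid on this carbon would read in this assay.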